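The compounds below may be only part of what the source reports. "The series", "measured", "known", "first", "only" and "open" are said of these compounds alone.

Measured so far:
Compound 1, `CCCCSc1n[nH]c(-n2[se]c3ccccc3c2=O)n1`, gives 30400 nM in an ADME assay on L929 cells (Mus musculus) for antiproliferative activity, read by CCK-8 assay, with a stated time of 48 h; a lower number here means a stronger inhibitor, a higher number a weaker inhibitor.
Compound 2, `CCSc1n[nH]c(-n2[se]c3ccccc3c2=O)n1`, gives 35200 nM in this assay.
Compound 3, `CCCCCSc1n[nH]c(-n2[se]c3ccccc3c2=O)n1`, gives 33500 nM in this assay.

The three measured compounds share one core and differ only in the length of the chain on the sulfur. Compound 1 and compound 3 differ by methyl in place of hydrogen on a saturated chain carbon, four bonds along the chain from a sulfur, and their numbers in this assay differ by a 1.1-fold higher number from compound 1 to compound 3 (0.04 log units; within the scatter). Compound 1 and compound 2 differ by hydrogen in place of ethyl on a saturated chain carbon, two bonds along the chain from a sulfur, and that change gave a 1.2-fold higher number from compound 1 to compound 2 (0.06 log units; within the scatter). The step from compound 2 to compound 3 was a 1.1-fold lower number from compound 2 to compound 3 (0.02 log units; within the scatter). Across these three compounds, then, the chain length has not moved the number beyond the scatter of the measurement.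

Compound 4, `CCCSc1n[nH]c(-n2[se]c3ccccc3c2=O)n1`, has not yet been measured. It differs from compound 3 by hydrogen in place of ethyl on a saturated chain carbon, three bonds along the chain from a sulfur. This is the same kind of change as that from compound 1 to compound 2, though not the same: there the change sat two bonds along the chain from a sulfur, here three bonds along the chain from a sulfur. Since the earlier change gave a 1.2-fold higher number from compound 1 to compound 2 (0.06 log units; within the scatter), and since compound 1, compound 2 and compound 3 all lie within the scatter of one another, the step from compound 3 to compound 4 in this assay is expected to be a 1.0-fold lower number from compound 3 to compound 4 (0.02 log units; within the scatter). Compound 4 is therefore estimated at 32000 nM, with a likely range from 20000 nM to 52000 nM.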

Compound 4, half-maximal inhibitory concentration: 31800 nM
For compound 4 the middle estimate is 1.0-fold (0.00 log units) above the measured one; low and high end bracket the measured number.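

With compound 4 included, the chain on the sulfur still has no effect beyond the scatter in this assay, with a 1.1-fold lower number from compound 3 to compound 4 (0.02 log units; within the scatter) and a 1.1-fold lower number from compound 2 to compound 4 (0.04 log units; within the scatter) and also a 1.0-fold higher number from compound 1 to compound 4 (0.02 log units; within the scatter), and hydrogen in place of ethyl gives matching results in its two instances: the same change on two cores in this assay, a 1.2-fold higher number (0.06 log units; within the scatter) from compound 1 to compound 2 and a 1.1-fold lower number (0.02 log units; within the scatter) from compound 3 to compound 4, 1.2-fold (0.09 log units) apart, within the scatter of two such steps. Methyl in place of hydrogen likewise gives matching results in its two instances: the same change on two cores in this assay, a 1.1-fold higher number (0.04 log units; within the scatter) from compound 1 to compound 3 and a 1.1-fold lower number (0.04 log units; within the scatter) from compound 2 to compound 4, 1.2-fold (0.09 log units) apart, within the scatter of two such steps. This shows that both changes carry over among these four compounds in the limited sense that every step stays within the scatter, but all four share one core outside the chain and none of the steps has a size that can be told from the scatter, so it does not show that a change with a clear effect would carry over, or that these changes would behave the same way on a different core.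

The compounds shown leave open whether a chain longer than pentyl, a branched chain, or a chain ending in an amine or a carboxylic acid would give a number outside the scatter of these four. They also leave open what a change to the shared core itself would do to the number.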